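A few compounds are considered here, and "the series" means these few. Any claim that something is new, unique, unknown or untested is made for them only; others in the source may bear on it.

Measured so far in a functional assay on HUVEC cells (Homo sapiens) for cytotoxicity; a higher number here means that more compound is needed for the effect, a lower number that less compound is needed:
Compound 1 `COC1=C(C)C(=O)/C(=C(O)/C=C/c2ccc(Br)cc2)C(=O)C1(C)C`: 3.6 ug/mL
Compound 2 `COC1=C(C)C(=O)/C(=C(O)/C=C/c2ccc(OC)cc2)C(=O)C1(C)C`: 2.5 ug/mL

Only these two numbers are available, and they do not separate. Compound 2, at 2.5 ug/mL, stands within the scatter of compound 1, at 3.6 ug/mL, so it holds no distinct place in this assay.

The next compound is compound 3 `COC1=C(C)C(=O)/C(=C(O)/C=C/c2cccc(OC)c2)C(=O)C1(C)C`, which has the same atoms as compound 2, joined differently: 3-methoxyphenyl in place of 4-methoxyphenyl on a double-bonded chain carbon bound to a double-bonded chain carbon. The methoxy group stays, and the change is 3-methoxyphenyl in place of 4-methoxyphenyl.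

For the measured compounds named here, only one measured step bears on this, and only loosely. It is a 1.4-fold lower number from compound 1 to compound 2 (0.16 log units; within the scatter), and it arises from methoxy in place of bromo on an aromatic carbon. Going by the values given here, that exchange of groups left the number within the scatter, but no measured pair shows this particular change, so the evidence is indirect. No step beyond the scatter is therefore expected, and no direction can be favoured. The expected step is a 1.1-fold higher number from compound 2 to compound 3 (0.05 log units; within the scatter). For compound 3 the estimated value is 2.8 ug/mL, with an expected range of 1.3 ug/mL to 6 ug/mL.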

Compound 3, concentration for half-maximal effect: 1.6 ug/mL
Compound 3: middle estimate off by 1.8-fold (0.24 log units), on the high side; low and high end bracket the measured number.
By their numbers in this assay, from the lowest: compounds 3, 2 and 1 (each within the scatter of the next, the first and the last beyond it).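

In this assay, 3-methoxyphenyl in place of 4-methoxyphenyl on a double-bonded chain carbon bound to a double-bonded chain carbon gives a 1.6-fold lower number from compound 2 to compound 3 (0.19 log units; within the scatter), so this first direct comparison of the two methoxyphenyl groups does not separate them. Set against the bromo compound, 3-methoxyphenyl in place of 4-bromophenyl at the same place gives a 2.3-fold lower number from compound 1 to compound 3 (0.35 log units; beyond the scatter), a modest step but the first among these compounds to clear the scatter, while compound 2 remains within the scatter of both compound 1 and compound 3. No measurement at hand accounts for this result, so the step stands as an observation only.

Compound 1 and compound 3 differ both in the group on the phenyl ring and in where it sits, and the compounds shown offer no pair that would tell these two changes apart. They also leave open how this assay would read with an amine or a carboxylic acid on that phenyl ring, or with a longer chain in place of the methoxy group.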